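The compounds below may be only part of what the source reports. "The series", "measured", "known", "first", "only" and "open" are said of these compounds alone.

In an ADME assay on HII4E cells (Mus musculus) for cytotoxicity, read by MTT assay, with a stated time of 48 h (a lower number here means a stronger inhibitor, a higher number a weaker inhibitor), compound 2 `CC(=O)OC[C@H]1O[C@H](OCC(=O)NCc2cn(Cc3ccccc3)nn2)[C@H](O)[C@@H](OC(C)=O)[C@H]1OC(C)=O` gives 879 ug/mL and holds the highest number of the three measured compounds. Compound 1 `CCOC(=O)/C=C1\C(OC(C)=O)=C[C@@H](COC(C)=O)O[C@@H]1OCC(=O)NCc1ccccc1` gives 128 ug/mL and compound 3 `C=CCCCCn1cc(CNC(=O)CO[C@H]2O[C@H](COC(C)=O)[C@H](OC(C)=O)[C@H](OC(C)=O)[C@H]2O)nn1` gives 63 ug/mL in the same read-out, and both gaps to compound 2 lie beyond the scatter.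

Compound 4 `CC(=O)OC[C@H]1O[C@H](OCC(=O)NCc2cn(Cc3ccccc3)nn2)[C@H](O)[C@@H](OC(C)=O)[C@@H]1OC(C)=O` carries one change against compound 2: the two compounds have the same atoms and bonds and differ only in configuration as drawn: 1 of 5 stereo elements differ; a stereocentre at a saturated ring carbon is drawn S in compound 2 and R in compound 4 and no group enters or leaves.

For the measured compounds named here, the single measured step of a 14-fold lower number from compound 2 to compound 3 (1.14 log units; beyond the scatter) puts pent-4-en-1-yl in place of phenyl on a saturated chain carbon bound to an aromatic nitrogen. That step is large but alters no configuration, so it gives no size for this change. Going by the values given here, no measured pair differs in configuration alone, and nothing sets a direction. No shift beyond the scatter is therefore expected in this assay and the range is kept wide. The expected step is a 1.2-fold lower number from compound 2 to compound 4 (0.07 log units; within the scatter) on this estimate. For compound 4 the estimated value is 750 ug/mL with an expected range from 300 ug/mL to 1600 ug/mL as the working figure.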

Compound 4, half-maximal inhibitory concentration: 69 ug/mL
For compound 4 the middle estimate is 11-fold (1.04 log units) above the measured one; the measured number lies below the stated range.
By their numbers in this assay, from the lowest: compounds 3, 4 and 1 (each within the scatter of the next, the first and the last beyond it); then compound 2.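

In this assay, the configuration at one saturated ring carbon is enough on its own to produce a large step, with R in place of S: a 13-fold lower number from compound 2 to compound 4 (1.11 log units; beyond the scatter). This size can be tied to the stereocentre because no group enters or leaves: the fact that compounds 2 and 4 differ only in the configuration as drawn. Compound 4 keeps the phenyl group, so the high number of compound 2 does not follow from phenyl alone, whereas the earlier step, a 14-fold lower number from compound 2 to compound 3 (1.14 log units; beyond the scatter), had changed that group while the configuration stayed the same.

From the compounds shown here alone, whether the R configuration would lower the number again with pent-4-en-1-yl in place of phenyl remains open. Also open, going by these compounds, is how this stereocentre would behave with a longer chain or a carboxylic acid on that side chain.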